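A few compounds are considered here, and "the series" means these few. Any claim that something is new, unique, unknown or untested is made for them only; others in the source may bear on it.

Measured so far:
- compound 1, `CCc1ccccc1C(=O)OC1CCN(C)CC1` — 1.15
- compound 2, `CN1CCC(OC(=O)c2ccccc2CCc2ccccc2)CC1` — 0.86

In a functional assay on the whole organism with Mus musculus as the target (a lower number here means a less potent compound, a higher number a more potent compound, by a factor of ten per unit of this negative logarithm), compound 1 gives 1.15, and compound 2 gives 0.86. Among the measured compounds shown here, the one step between them, a number 0.29 log units lower from compound 1 to compound 2 (within the scatter), is within the scatter, so compound 2 stands lowest of the two numbers only nominally; its nearest neighbour is compound 1, and the two cannot be ordered.

Compound 3, `CN1CCC(OC(=O)c2ccccc2-c2ccccc2)CC1`, is not yet measured in this assay. It differs from compound 2 by phenyl in place of phenethyl on an aromatic carbon. For the measured compounds named here, the only measured step touching this region of the shared core is a number 0.29 log units lower from compound 1 to compound 2 (within the scatter), which added a phenyl to the saturated chain and moved the number by less than the scatter. Going by the values given here, no measured pair shows a phenyl put directly on the aromatic carbon, so that change is uncovered by the data. Given the smallness of the one step seen, the expectation is a change in this assay of no more than the scatter in either direction, a number 0.14 log units higher from compound 2 to compound 3 (within the scatter). Compound 3 is therefore estimated at 1, with a range of 0.5 to 1.5.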

Compound 3, logarithm of the reciprocal of the active concentration, log(1/C): 1.52
The estimate for compound 3 lay 0.52 log units below the measured number, and the stated range ends below it.
By their numbers in this assay, from the lowest: compounds 2 and 1 (each within the scatter of the next); then compound 3.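

Among the compounds shown here, on the aromatic carbon ortho to a large group, phenyl is the first group to move the number in this assay beyond the scatter, both in place of phenethyl (a number 0.66 log units higher from compound 2 to compound 3 (beyond the scatter)) and in place of ethyl (a number 0.37 log units higher from compound 1 to compound 3 (beyond the scatter)). Both steps are modest, but they go in the same direction, while compound 1 and compound 2, which both carry a saturated chain at this carbon, cannot be ordered; among these three compounds, only the one with the ring attached directly to the aromatic carbon stands apart. No measurement available here accounts for this difference.

On these data alone, it remains open whether a benzyl group at this carbon would group with the two chain compounds or with compound 3, and whether a pyridyl ring or a phenyl carrying chlorine or methoxy would keep the number of compound 3. The ester is common to all three compounds, so it is also unknown whether this order would hold with an amide in its place.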